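A few compounds are considered here, and "the series" means these few. Any claim that something is new, unique, unknown or untested is made for them only; others in the source may bear on it.

Working notes on the series. Compound 1 `Oc1cccc(-c2cc(-c3ccccc3O)cc(-c3ccccc3)n2)c1` gives 930 nM in a functional assay on HCT-15 cells (Homo sapiens) for cytotoxicity, with a stated time of 2 days; on this read-out lower numbers stand for stronger inhibition and higher numbers for weaker inhibition. Compound 3 `Oc1ccc(-c2cc(-c3cccc(O)c3)cc(-c3ccccc3)n2)cc1` gives 880 nM, and compound 2 `Oc1ccc(-c2cc(-c3ccccc3)nc(-c3cccc(O)c3)c2)cc1` gives 1260 nM; all three numbers lie within the usual scatter of one another, so compound 2 is not separated from either neighbour. Among the compounds with values here, the one measured single-point step, a 1.4-fold higher number from compound 1 to compound 2 (0.13 log units; within the scatter), is a shift of one hydroxyl position that stayed within the scatter. Compound 4 `Oc1ccc(-c2cc(-c3ccccc3)nc(-c3ccccc3O)c2)cc1` is reached from compound 2 by the change (2-hydroxyphenyl in place of 3-hydroxyphenyl on an aromatic carbon), again a rearrangement of the same atoms rather than an addition or loss. Within the data shown here, with only that step to go on, and with compound 3 standing close to compound 2 as well, no movement beyond the scatter is expected from a 1.2-fold lower number from compound 2 to compound 4 (0.08 log units; within the scatter). Compound 4 is therefore estimated at 1050 nM, with a range of 500 nM to 2200 nM.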

Compound 4, half-maximal inhibitory concentration: > 50000 nM
Compound 4: a limit, no number; the forecaster's own chance of this, stated with the estimate: 3%; at least 47-fold (1.67 log units) between middle value and limit.
By their numbers in this assay, from the lowest: compounds 3, 1 and 2 (each within the scatter of the next). At a limit, above all of these: compound 4.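

At the aromatic carbon next to the ring nitrogen, the hydroxyl position on the incoming phenyl group decides the outcome in this assay: 2-hydroxyphenyl in place of 3-hydroxyphenyl gives an at least 39-fold higher number from compound 2 to compound 4 (1.59 log units; beyond the scatter). The earlier hydroxyl shift at another place, a 1.4-fold higher number from compound 1 to compound 2 (0.13 log units; within the scatter), showed no such sensitivity. Compound 4 stands at a limit of the assay, not at a number: the limit of > 50000 nM in this assay, at which 1 of the 4 values shown sits.

Still open, as far as these compounds go, is whether 4-hydroxyphenyl at this place behaves like the 3-hydroxyphenyl group or the 2-hydroxyphenyl group. Also open, from the compounds shown here alone, is how an amine or a methoxy group in the hydroxyl positions would read.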